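The source may report more compounds than this note shows. Statements on the series, on what has been measured and on what is new or still open speak of the compounds shown alone.

Of the compounds shown here, three have been measured in a functional assay on SGC-7901 cells (Homo sapiens) for antiproliferative activity, read by MTT assay, with a stated time of 24 h; on this read-out higher numbers stand for weaker inhibition and lower numbers for stronger inhibition: compound 1 `Cc1ccc(-n2cc(-c3ccccc3NS(=O)(=O)c3c[nH]c(=O)[nH]c3=O)nn2)cc1` gives 6390 nM, compound 2 `O=c1[nH]cc(S(=O)(=O)Nc2ccccc2-c2cn(-c3ccccc3F)nn2)c(=O)[nH]1` gives 10800 nM, and compound 3 `Cc1ccc(-n2cc(-c3cccc(NS(=O)(=O)c4c[nH]c(=O)[nH]c4=O)c3)nn2)cc1` gives 9430 nM.

Compound 1 and compound 2 share a core and differ in one place: 2-fluorophenyl in place of 4-methylphenyl on an aromatic nitrogen. This change gave a 1.7-fold higher number from compound 1 to compound 2 (0.23 log units; within the scatter). Compound 1 and compound 3 are built from the same atoms joined differently, and the difference between the two cores is not broken down here. The values of compound 3 and compound 2 lie within the scatter of one another, as do those of compound 3 and compound 1, so none of the three can be set apart from the others on this read-out.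

Compound 4 `O=c1[nH]cc(S(=O)(=O)Nc2cccc(-c3cn(-c4ccccc4F)nn3)c2)c(=O)[nH]1` has not yet been measured. It differs from compound 3 in one place: 2-fluorophenyl in place of 4-methylphenyl on an aromatic nitrogen. Among the measured compounds shown here, this is the same change as the one from compound 1 to compound 2, made here on the core of compound 3, and the surroundings of the place are described in the same words. Because a 1.7-fold higher number from compound 1 to compound 2 (0.23 log units; within the scatter) stayed within the scatter, the step from compound 3 to compound 4 is expected to be small as well, a 1.5-fold higher number from compound 3 to compound 4 (0.17 log units; within the scatter). Compound 4 is therefore estimated at 14000 nM in this assay, with a likely range from 7000 nM to 28000 nM.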

Compound 4, half-maximal inhibitory concentration: 16000 nM
Compound 4: the middle estimate sits 1.1-fold (0.06 log units) below what was measured; the measured number falls inside the stated range.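

In this assay, putting 2-fluorophenyl in place of 4-methylphenyl on the aromatic nitrogen gave a 1.7-fold higher number from compound 3 to compound 4 (0.23 log units; within the scatter). Set beside the earlier step, the same change reads alike on the two cores: the same change on two cores in this assay, a 1.7-fold higher number (0.23 log units; within the scatter) from compound 1 to compound 2 and a 1.7-fold higher number (0.23 log units; within the scatter) from compound 3 to compound 4, 1.0-fold (0.00 log units) apart, within the scatter of two such steps. This shows that, between these two cores, the swap carried over with no detectable difference, but each step is small enough to be ordinary repeat variation, so the agreement does not prove that the swap has a real effect on either core, and two cores cannot show that it would carry over to others in the series.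

The compounds shown place only 4-methylphenyl and 2-fluorophenyl on this nitrogen, so they give no sign of what a phenyl ring carrying an amine or a carboxylic acid would do, or a longer chain such as butyl. As far as these compounds go, it remains open whether any group at this place can give a step that clearly exceeds the scatter.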